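Bromo for Fluoro on the Aryl Ring of Compound 2

The source may report more compounds than this note shows. Statements on the series, on what has been measured and on what is new or still open speak of the compounds shown alone.

Two measured compounds frame this account. Compound 1 `CCOC(=O)N/C(=N\CCC(c1ccc(F)cc1)c1ccccn1)NCCCc1c[nH]cn1` carries an ethoxycarbonyl on an amine nitrogen, and in a functional assay on ileum for antagonist activity at histamine H1 receptor (Cavia porcellus) (on this read-out higher numbers stand for higher potency (the scale is a negative logarithm) and lower numbers for lower potency), compound 1 gives 5.3. Compound 2 `CN/C(=N\CCC(c1ccc(F)cc1)c1ccccn1)NCCCc1c[nH]cn1` carries a methyl in its place; in this assay compound 2 gives 5.08. For the measured compounds named here, the only measured step, a number 0.22 log units lower from compound 1 to compound 2 (within the scatter), is within the scatter, so compound 2 stands at the lower of the two numbers without standing apart from compound 1.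

Compound 3 `CN/C(=N\CCC(c1ccc(Br)cc1)c1ccccn1)NCCCc1c[nH]cn1` differs from compound 2 in one place: bromo in place of fluoro on an aromatic carbon. Going by the values given here, no measured step touches this aromatic carbon; the single step from compound 1 to compound 2 concerns the amine nitrogen and therefore bears on the present change only as a sign that this scaffold tolerates a small substitution without moving beyond the scatter. No shown step supports a shift in either direction for compound 3.

Compound 3 is therefore expected to give about 5.1 in this assay, with a range from 4.6 to 5.6, meaning an estimated step of a number 0.02 log units higher from compound 2 to compound 3 (within the scatter).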

Compound 3, negative logarithm of the antagonist equilibrium constant: 5.71
The estimate for compound 3 lay 0.61 log units below the measured number; measured number outside the range, above it.
By their numbers in this assay, from the lowest: compounds 2 and 1 (each within the scatter of the next); then compound 3.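

The aromatic carbon that carries the halogen proves to be a place where this series responds. In this assay, for the compounds shown here, the change from 4-fluorophenyl to 4-bromophenyl comes with a number 0.63 log units higher from compound 2 to compound 3 (beyond the scatter) and clears the scatter, which the one earlier step at the amine nitrogen, a number 0.22 log units lower from compound 1 to compound 2 (within the scatter), did not do. The exchange swaps one heavy atom for one heavy atom, with no ring, no hydrogen-bond donor or acceptor and no net charge entering or leaving, so these counts do not separate the two halogens even though the measured numbers do, and no measurement available here bears on the reason for the difference.

The compounds shown leave open how chloro, iodo, methyl or trifluoromethyl would read on the same aromatic carbon, and so whether the rise follows bromo alone or extends to other groups there. They also leave open whether bromo brings a similar step when ethoxycarbonyl stands on the amine nitrogen in place of methyl.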